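The source may report more compounds than this note shows. Statements on the series, on what has been measured and on what is new or still open speak of the compounds shown alone.

Working notes on the series. Compound 1 `NC(=O)c1cnc(C(=O)CCc2ccc(Oc3ccccc3)cc2)o1` and compound 2 `O=C(CCc1ccc(Oc2ccccc2)cc1)c1ncc(I)o1` share the same core and differ only in the group on the five-membered aromatic ring. In an assay for inhibition of Fatty-acid amide hydrolase 1 (Rattus norvegicus) (on this read-out higher numbers stand for weaker inhibition and lower numbers for stronger inhibition), compound 1 gives 6.6 nM; in this assay compound 2 gives 10 nM. Within the data shown here, compound 2 thus shows the higher of the two numbers measured so far, with compound 1 nearest, but the step of a 1.5-fold higher number from compound 1 to compound 2 (0.18 log units; within the scatter) lies within the scatter, so no order between them is claimed.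

Compound 3 `CNC(=O)c1cnc(C(=O)CCc2ccc(Oc3ccccc3)cc2)o1` is the next member: methylcarbamoyl in place of iodo on an aromatic carbon. Among the measured compounds shown here, the only measured step that bears on this change is a 1.5-fold higher number from compound 1 to compound 2 (0.18 log units; within the scatter), which exchanged carbamoyl for iodo at the same place and stayed within the scatter. Compound 3 carries the methylcarbamoyl group at that place, so the return from iodo is expected to move the number little, with a 1.3-fold lower number from compound 2 to compound 3 (0.10 log units; within the scatter) expected. For compound 3 the estimate in this assay is 8 nM, within the range 3 nM to 25 nM.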

Compound 3, inhibition constant: 11 nM
Beside the measured number, compound 3's estimate is 1.4-fold (0.14 log units) below it, within the range that was stated.
By their numbers in this assay, from the lowest: compounds 1, 2 and 3 (each within the scatter of the next).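

In this assay, methylcarbamoyl in place of iodo on the aromatic carbon next to the ring oxygen gives a 1.1-fold higher number from compound 2 to compound 3 (0.04 log units; within the scatter), so a group of 4 heavy atoms with a hydrogen-bond donor and acceptor cannot be told apart from a single iodine at this place. Methyl in place of hydrogen on the amide-type nitrogen, a change the earlier compounds did not include, gives a 1.7-fold higher number from compound 1 to compound 3 (0.22 log units; within the scatter), so carbamoyl, methylcarbamoyl and iodo give no order here, and the amide hydrogen shows no measurable role in this assay. No available evidence bears on why these groups read alike.

The compounds shown leave open whether any group at this place moves the number beyond the scatter. A carboxylic acid, an amine or a longer chain on the amide-type nitrogen would test this.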